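A few compounds are considered here, and "the series" means these few. Any claim that something is new, unique, unknown or untested is made for them only; others in the source may bear on it.

Among the compounds with values here, in a functional assay on HCT-116 cells (Homo sapiens) for inhibition, read by MTT assay, with a stated time of 72 h (a lower number here means that less compound is tolerated, a higher number that more compound is tolerated), compound 1 (`O=C1C=CC(O)(c2cc3ccccc3n2S(=O)(=O)c2ccccc2)C=C1`) gives 30 nM, the only exact number so far. Compound 2 (`O=C1C=CC(O)(c2cc3ccc(F)cc3n2S(=O)(=O)c2ccccc2)C=C1`) is reported only as a limit, < 10 nM. Compound 3 (`Cc1ccc(S(=O)(=O)n2c(C3(O)C=CC(=O)C=C3)cc3ccccc32)cc1`) keeps the core of compound 1 and differs from it by methyl in place of hydrogen on an aromatic carbon, para to a large group, turning phenyl to 4-methylphenyl. Within the data shown here, only one measured step bears on this change, an at least 3.0-fold lower number from compound 1 to compound 2 (0.47 log units; beyond the scatter), which is fluoro in place of hydrogen on an aromatic carbon. That step involves a different group and its size is bounded by a limit, so it offers only weak guidance. In this assay, the expected result is therefore no shift beyond the scatter, with an estimated 1.2-fold lower number from compound 1 to compound 3 (0.08 log units; within the scatter). For compound 3 the expected value is 25 nM, with an estimated range of 10 nM to 70 nM.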

Compound 3, concentration lethal to 50% of the cells: < 10 nM
Compound 3: no number, only a limit; the forecaster's own chance of this, stated with the estimate: 15%; middle value at least 2.5-fold (0.39 log units) away from the limit.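

Turning phenyl to 4-methylphenyl, with methyl on an aromatic carbon para to a large group, gives an at least 3.0-fold lower number from compound 1 to compound 3 (0.47 log units; beyond the scatter) in this assay, so a change at this ring, a different place from the fluoro of compound 2, also moves the number beyond the scatter. Compound 3 is reported only as a limit, < 10 nM, and not as a number. The step therefore has a lower bound but no known full size, because the reading stops at the edge of the assay: the limit of < 10 nM in this assay, at which 2 of the 3 values shown sit.

Going by these compounds, whether this shift belongs to methyl itself or would also appear with another group on the same carbon, such as methoxy, an amine or a carboxylic acid, remains open. Also open, on these data alone, is whether fluoro at this carbon would give a step like that of methyl.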